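Compound 3 to compound 4: reshaping the charged group

The source may report more compounds than this note shows. Statements on the series, on what has been measured and on what is new or still open speak of the compounds shown alone.

Measured in a functional assay on HepG2 cells (Homo sapiens) for cytotoxicity, read by MTT assay, with a stated time of 48 h (a lower number here means a stronger inhibitor, a higher number a weaker inhibitor), so far:
Compound 1 `CC1=NN(C(=O)CN2CCC(Cl)CC2)C(c2ccccc2O)C1` gives 42100 nM
Compound 2 `COc1ccccc1C1CC(C)=NN1C(=O)CN1CCC(OC)CC1` gives 22000 nM
Compound 3 `CC[N+](C)(CC)CC(=O)N1N=C(C)CC1c1ccccc1OC` gives 3670 nM

Compound 3 has the lowest number of the three, and its gaps to compound 2 and compound 1 both lie beyond the scatter. The next compound to be tested is compound 4 `COc1ccccc1C1CC(C)=NN1C(=O)C[N+]1(C)CCCC1`, and the change from compound 3 is a group of 6 heavy atoms (5 carbon, 1 nitrogen; one five-membered non-aromatic ring with 1 hetero atom) in place of a group of 6 heavy atoms (5 carbon, 1 nitrogen; no ring), on a saturated chain carbon bound to a carbonyl carbon on a saturated chain carbon bound to a carbonyl carbon. Leaving and entering groups both have net charge +1. The entering group holds one five-membered non-aromatic ring with 1 hetero atom, while the leaving group has no ring.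

For the measured compounds named here, only one measured step touches this place: a 6.0-fold lower number from compound 2 to compound 3 (0.78 log units; beyond the scatter). That step is modest, and it also changed the size of the group. Going by the values given here, a single step gives no rule for ring against no ring, and no measured step links compound 1 to the others. A change that keeps the heavy-atom count and the net charge should be smaller than that step. The expected step is a 1.4-fold higher number from compound 3 to compound 4 (0.13 log units; within the scatter) and it is estimated to stay within the scatter, with a slight rise at most. In this assay the expected value of compound 4 is 5000 nM with an estimated range from 1800 nM to 14000 nM.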

Compound 4, half-maximal inhibitory concentration: 32200 nM
For compound 4 the middle estimate is 6.4-fold (0.81 log units) below the measured one; the whole stated range lies below it.
By their numbers in this assay, from the lowest: compound 3; then compounds 2, 4 and 1 (each within the scatter of the next).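

In this assay, tying the open charged group into one five-membered non-aromatic ring with 1 hetero atom, at the same heavy-atom count and the same net charge, gives an 8.8-fold higher number from compound 3 to compound 4 (0.94 log units; beyond the scatter); on a saturated chain carbon bound to a carbonyl carbon, the number therefore follows the shape of the group and not only its size or charge. The second step, a 1.5-fold higher number from compound 2 to compound 4 (0.17 log units; within the scatter), stays within the scatter, so the ring group of compound 4 and the six-membered ring group of compound 2 cannot be told apart here, and a net charge of +1 does not by itself go with the lowest number, as compound 4 carries that charge as well as compound 3. No measurement on these compounds bears on what lies behind the step from the open group to the ring.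

As far as these compounds go, it remains open whether the low number of compound 3 depends on its open chain as such or on its two ethyl groups, which a trimethylammonium group or a six-membered piperidinium ring would help to separate. The core of compound 1 also remains open, as nothing shown places an open or ring-shaped charged group on it.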